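A Phenyl for a Hydroxymethyl on the Side Chain

The compounds below may be only part of what the source reports. "The series", "measured", "known", "first", "only" and "open" are said of these compounds alone.

Compound 1 `CSc1nc(NCCCCCO)c2ccccc2n1` carries a 5-hydroxypentyl chain on a nitrogen of the shared core. In a functional assay on HT-29 cells (Homo sapiens) for cytotoxicity, read by MTT assay, with a stated time of 72 h (on this read-out higher numbers stand for weaker inhibition of growth and lower numbers for stronger inhibition of growth), compound 1 gives > 100000 nM, which is a limit of the assay rather than a number. Compound 2 `COc1ccc(CNc2nc(SC)nc3ccccc23)cc1` likewise reaches only the limit > 100000 nM in this assay. Compound 3 `CSc1nc(Nc2ccccc2)c2ccccc2n1` also sits at the limit > 100000 nM in this assay. The step that the two limits leave unreadable from compound 1 to compound 3 therefore cannot be read. All three values share (the limit of > 100000 nM in this assay, at which 3 of the 3 values shown sit). Compound 4 `CSc1nc(NCCCCc2ccccc2)c2ccccc2n1` differs from compound 1 in one place: phenyl in place of hydroxymethyl on a saturated chain carbon, four bonds along the chain from a nitrogen on an aromatic ring. Within the data shown here, no measured step gives a readable size here, so no direction beyond the scatter is expected. Compound 4 is expected to give 150000 nM, between 50000 nM and 500000 nM, most likely again a limit. The expected step that the limit leaves unreadable from compound 1 to compound 4 is thus estimated to be flat.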

Compound 4, concentration for total growth inhibition: > 100000 nM
Compound 4: a limit, no number (the forecaster's own chance of this, stated with the estimate: 75%); the middle value lies beyond the limit too.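

Among these compounds, compound 1 and compound 4 both stand at a limit of the assay, not a number, so no step between them can be read: the limit of > 100000 nM in this assay, at which 4 of the 4 values shown sit. The compounds shown leave open which change to the side chain, if any, would give a readable value in this assay.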